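From pyridin-2-yl to phenyl: estimating plasma exposure

A few compounds are considered here, and "the series" means these few. Any claim that something is new, unique, unknown or untested is made for them only; others in the source may bear on it.

Compound 1 `C[C@@H](Sc1nc2c(cnn2C)c(=O)n1-c1ccccc1)c1ccccc1`: 300 nM
Compound 2 `CC(Sc1nc2c(cnn2C)c(=O)n1-c1ccccc1)c1ccccn1`: 3900 nM
Compound 3 `CC(Sc1nc2c(cnn2C)c(=O)n1-c1ccccc1)c1ccccc1`: not yet measured

Among the compounds with values here, in an ADME assay on the whole organism (Mus musculus, strain CD-1) for pharmacokinetics, read by LC-MS, with a stated time of 7 h, at a dose of 10 mg/kg by the intraperitoneal route (on this read-out lower numbers stand for lower exposure and higher numbers for higher exposure at the dose given), compound 2 holds the higher of the two numbers so far, at 3900 nM. Compound 3 differs from compound 2 in one place: phenyl in place of pyridin-2-yl on a saturated chain carbon bound to a saturated chain carbon and a sulfur. Within the data shown here, only one measured step bears on this change: a 13-fold higher number from compound 1 to compound 2 (1.11 log units; beyond the scatter). That step put 1-(pyridin-2-yl)ethyl in place of 1-phenylethyl on a sulfur. The new change runs the same swap in the opposite direction and gives compound 3 the 1-phenylethyl group that compound 1 also carries. A single pair is thin evidence, and the size of a step need not repeat exactly. Even so, the large size of that one step points to a large fall in this assay, well beyond the scatter. The expected result is a 12-fold lower number from compound 2 to compound 3 (1.07 log units; beyond the scatter). Compound 3 is estimated at 330 nM, with an expected range from 130 nM to 900 nM.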

Compound 3, maximal plasma concentration: 2300 nM
Beside the measured number, compound 3's estimate is 7.0-fold (0.84 log units) below it; measured number above the stated range.
By their numbers in this assay, from the lowest: compound 1; then compounds 3 and 2 (each within the scatter of the next).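

In this assay, the swap of pyridin-2-yl for phenyl, with neither compound drawn with a configuration at the chain carbon, gives a 1.7-fold lower number from compound 2 to compound 3 (0.23 log units; within the scatter), so at this position the ring change alone leaves no readable difference. The earlier step, a 13-fold higher number from compound 1 to compound 2 (1.11 log units; beyond the scatter), therefore cannot be read as a ring effect alone: besides the ring, compound 1 is drawn with a configuration at that carbon and compound 2 without one. The pair with identical atoms and bonds gives a 7.7-fold higher number from compound 1 to compound 3 (0.88 log units; beyond the scatter), which leaves only one difference standing: the fact that one of compounds 1 and 3 is drawn with a defined configuration and the other without, at the place where they differ.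

Still open, going by these compounds, is how the form with the opposite configuration would read, and whether the separate forms of compound 2 would show a similar gap. Also open, on these data alone, is how a pyridin-3-yl or pyridin-4-yl ring, or a longer chain in place of the ethyl, would read at this position.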